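This account rests on a few compounds, and the source may have more. Where it says the series, first, only, none or still open, it means among the compounds named here.

Of the compounds shown here, three carrying the same core have been measured in an assay on isolated protein for inhibition of Amine oxidase [flavin-containing] B (Homo sapiens), read by fluorescence, with a stated time of 30 min; on this read-out higher numbers stand for weaker inhibition and lower numbers for stronger inhibition. Compound 1, `CC(=O)c1ccc(OCCCCCCCCCCN2CCC(Cc3ccccc3)CC2)cc1O`, gives 21600 nM. Compound 3, `CC(=O)c1ccc(OCCCCCCCCCCCCN2CCC(Cc3ccccc3)CC2)cc1O`, gives 25800 nM. Compound 2, `CCN(CCCCCCCCCCCCOc1ccc(C(C)=O)c(O)c1)Cc1ccccc1`, gives 33100 nM. The gap from compound 1 to compound 3 and the gap from compound 1 to compound 2 both lie within the scatter of this assay, so the three numbers cannot be set in any order, and none of the three can be called stronger or weaker than the others.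

Compound 4, `CC(=O)c1ccc(OCCCCCCCCCCN2CCC(c3ccccc3)CC2)cc1O`, has not yet been measured. It differs from compound 1 in one place: phenyl in place of benzyl on a saturated ring carbon. Among the measured compounds shown here, no step between two measured compounds shows what such an exchange does here, so the direction of the change in this assay is unknown. With all three measured numbers lying so close together, the expectation for compound 4 is a number near that of compound 1, and the estimated step of a 1.2-fold higher number from compound 1 to compound 4 (0.06 log units; within the scatter) is expected to stay within the scatter. Compound 4 is therefore estimated at 25000 nM, with a range from 10000 nM to 60000 nM.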

Compound 4, half-maximal inhibitory concentration: 14200 nM
Compound 4: middle estimate off by 1.8-fold (0.25 log units), on the high side; measured number inside the range.
By their numbers in this assay, from the lowest: compounds 4, 1, 3 and 2 (each within the scatter of the next, the first and the last beyond it).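

In this assay the exchange of benzyl for phenyl on the saturated ring carbon, three ring bonds from the ring nitrogen, gives a 1.5-fold lower number from compound 1 to compound 4 (0.18 log units; within the scatter). Among the compounds shown here, this is the first reading at this position, and it shows that losing the one carbon that benzyl has and phenyl lacks brings no change that can be told from scatter, so the aromatic ring can sit directly on the saturated ring with the number staying in the same range. No measurement available here speaks to what lies behind this result.

As far as these compounds go, whether a longer link such as phenethyl, or an amine or a carboxylic acid on this carbon, would move the number beyond the scatter stays open. So does whether the same exchange gives a similar step on the longer chain of compound 3.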